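Swapping One Fluoro-Methoxyphenyl Group for Another

The compounds below may be only part of what the source reports. "The series", "measured", "known", "first", "only" and "open" are said of these compounds alone.

In a functional assay on THP-1 cells (Homo sapiens) (on this read-out lower numbers stand for stronger inhibition and higher numbers for weaker inhibition), compound 1 `CC[C@H]1c2c(cc(F)c(F)c2O)[C@H](Nc2cccc3[nH]c(=O)ccc23)[C@@](O)(C(F)(F)F)C1OC` gives 6.31 nM, compound 2 `CCSC[C@@](O)([C@@H](Nc1cccc2nc(C)ccc12)c1ccc(C)cc1)C(F)(F)F` gives 2.51 nM and compound 3 `CCSC[C@@](O)([C@@H](Nc1cccc2nc(C)ccc12)c1cccc(F)c1OC)C(F)(F)F` gives 2 nM. Compound 3 therefore sits at the low end of these numbers, within the scatter of compound 2 and beyond the scatter from compound 1.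

Compound 4 `CCSC[C@@](O)([C@@H](Nc1cccc2nc(C)ccc12)c1ccc(OC)cc1F)C(F)(F)F` has the same atoms as compound 3, joined differently: 2-fluoro-4-methoxyphenyl in place of 3-fluoro-2-methoxyphenyl on a saturated chain carbon bound to a nitrogen on an aromatic ring and a saturated chain carbon. It carries 2-fluoro-4-methoxyphenyl in place of 3-fluoro-2-methoxyphenyl on a saturated chain carbon bound to a nitrogen on an aromatic ring and a saturated chain carbon.

Within the data shown here, one measured step bears on this place, where 3-fluoro-2-methoxyphenyl replaced 4-methylphenyl: a 1.3-fold lower number from compound 2 to compound 3 (0.10 log units; within the scatter). Among the measured compounds shown here, that step stays within the scatter, but no measurement yet tests 2-fluoro-4-methoxyphenyl itself, so some uncertainty remains. No change beyond the scatter is therefore expected in this assay. The expected step is a 1.3-fold higher number from compound 3 to compound 4 (0.10 log units; within the scatter).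

The estimated value for compound 4 is 2.5 nM, with an expected range from 1 nM to 6.5 nM.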

Compound 4, half-maximal inhibitory concentration: 5.01 nM
Compound 4: the middle estimate sits 2.0-fold (0.30 log units) below what was measured, within the range that was stated.
By their numbers in this assay, from the lowest: compounds 3, 2, 4 and 1 (each within the scatter of the next, the first and the last beyond it).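

In this assay, this position proves sensitive to how the same atoms are arranged on the phenyl ring, not only to which atoms are present: 2-fluoro-4-methoxyphenyl in place of 3-fluoro-2-methoxyphenyl gives a 2.5-fold higher number from compound 3 to compound 4 (0.40 log units; beyond the scatter) even though both groups have the same atom counts. Set against 4-methylphenyl, the same group gives a 2.0-fold higher number from compound 2 to compound 4 (0.30 log units; within the scatter), so compound 2 lies within the scatter of both fluoro-methoxy compounds and only the two isomers can be told apart. Nothing available here explains why this rearrangement matters.

Among these compounds, still open is how far this sensitivity extends, since only three groups at this position can be compared on this shared core. A phenyl ring carrying an amine or a carboxylic acid, or a pyridine ring, could show whether the position tolerates larger changes.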